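Methylating a Ring Amide Nitrogen in a Cyclic Peptide

This account rests on a few compounds, and the source may have more. Where it says the series, first, only, none or still open, it means among the compounds named here.

Compound 1 `C[C@@H]1NC(=O)CNC(=O)[C@@H](Cc2ccc(O)cc2)NC(=O)[C@H](CCCNC(=N)N)NC(=O)[C@H](CCCNC(=N)N)NC1=O`: in an assay on CHO cells for binding affinity to C-X-C chemokine receptor type 4 (Homo sapiens) (a lower number here means a stronger inhibitor, a higher number a weaker inhibitor), compound 1 gives > 1000 nM, which is a limit of the assay and not a number.
Compound 2 `C[C@@H]1NC(=O)CNC(=O)[C@@H](Cc2ccc(O)cc2)NC(=O)[C@@H](CCCNC(=N)N)NC(=O)[C@H](CCCNC(=N)N)NC1=O`: in this assay compound 2 gives > 1000 nM, again a limit and not a number.

For the measured compounds named here, compound 1 therefore stands only at a limit in this assay, and the one further value shown, that of compound 2, is a limit as well. Going by the values given here, the single measured step, a step that the two limits leave unreadable from compound 1 to compound 2, cannot be read because the limit of > 1000 nM in this assay, at which 2 of the 2 values shown sit, puts both values at the same limit. Compound 3 `C[C@@H]1NC(=O)CN(C)C(=O)[C@@H](Cc2ccc(O)cc2)NC(=O)[C@H](CCCNC(=N)N)NC(=O)[C@H](CCCNC(=N)N)NC1=O` differs from compound 1 by methyl in place of hydrogen on an amide-type nitrogen in a ring. No measured step covers such a change, and the one step shown has no readable size, so no direction beyond the scatter can be expected for the step from compound 1 to compound 3 in this assay. Compound 3 is expected to give 3000 nM (range 800 nM to 15000 nM), an expected step that the limit leaves unreadable from compound 1 to compound 3, and most likely the assay will again report only a limit.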

Compound 3, half-maximal inhibitory concentration: 167 nM
Estimate against measurement, compound 3: 18-fold (1.25 log units) above; measured number below the stated range.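

In this assay, methyl in place of hydrogen on this amide-type nitrogen in a ring gives an at least 5.9-fold lower number from compound 1 to compound 3 (0.77 log units; beyond the scatter), and compound 3 is the only compound shown whose result is a number and not a limit. This position, two ring bonds from the ring atom that bears the 4-hydroxybenzyl group, therefore responds to a change of a single heavy atom, which compounds 1 and 2 could not show. From the compounds shown here alone, the full size of the step remains unknown because only one of its two ends is a number: the limit of > 1000 nM in this assay, at which 2 of the 3 values shown sit.

The compounds shown leave open whether an ethyl group or a longer chain on this same nitrogen would give a lower or a higher number than methyl. They also leave open what methyl would do on the other ring nitrogens, or on this nitrogen in compound 2.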